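The source may hold more compounds than are shown below. What is called first, only, known or untested is meant among the compounds shown, and "the series" means these compounds.

Measured so far:
compound 1, `COc1ccc(CNc2nc([Se]C)nc3ccccc23)cc1`: > 100000 nM
compound 2, `CSc1nc(NCCCc2ccccc2)c2ccccc2n1`: 73400 nM

In an ADME assay on BEAS-2B cells (Homo sapiens) for cytotoxicity, read by MTT assay, with a stated time of 72 h (a higher number here means a weaker inhibitor of growth, a lower number a stronger inhibitor of growth), compound 1 gives > 100000 nM, which is a limit of the assay and not a number. In this assay compound 2 gives 73400 nM. Compound 2 therefore stands as the only plain number shown here. The other value shown is the limit of > 100000 nM in this assay, at which 1 of the 2 values shown sits.

Compound 3, `CSc1nc(NCCCCc2ccccc2)c2ccccc2n1`, has not yet been measured in this assay. It differs from compound 2 by benzyl in place of phenyl on a saturated chain carbon, three bonds along the chain from a nitrogen on an aromatic ring. No step between two measured compounds is shown, so there is no measured guide to how a change of this kind moves the number in this assay. A change of this kind is expected to move the number in this assay little, if at all, and most likely within the usual scatter. In this assay compound 3 is expected to give 60000 nM, with a range from 25000 nM to 150000 nM. The expected step is a 1.2-fold lower number from compound 2 to compound 3 (0.09 log units; within the scatter).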

Compound 3, concentration for 50% growth inhibition: 6810 nM
Beside the measured number, compound 3's estimate is 8.8-fold (0.95 log units) above it; measured number below the stated range.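

Replacing phenyl with benzyl on this saturated chain carbon gives an 11-fold lower number from compound 2 to compound 3 (1.03 log units; beyond the scatter) in this assay. Among these compounds, the earlier compounds offered no measured step, so this is the first sign that the number responds strongly to a change at this place, even though the aromatic ring stays and the hydrogen-bond donor, acceptor and charge counts of the two groups are the same. Nothing measured here accounts for the size of this step.

A single step cannot show whether a longer chain would lower the number further, leave it unchanged or raise it again. It also leaves open how the number would respond to an amine or a carboxylic acid placed at the end of the chain in place of the aromatic ring.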